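This account rests on a few compounds, and the source may have more. Where it says the series, first, only, none or still open, it means among the compounds named here.

In an assay for binding affinity to Apoptosis regulator Bcl-2 (Homo sapiens), read by fluorescence polarization, with stated times of 30 min and 20 min, tested at 100 uM (a lower number here means less inhibition, a higher number more inhibition at the concentration tested (going by the name of the read-out)), compound 2, with the structure `COc1ccc(Oc2ccccc2-c2ccsc2S(=O)(=O)N2CCN(C(=S)Nc3cc(C(F)(F)F)cc(C(F)(F)F)c3)CC2)cc1OC`, gives 25%. Going by the values given here, the only other measured compound, compound 1, with the structure `O=[N+]([O-])c1ccc(NC(=S)N2CCN(S(=O)(=O)c3sccc3-c3ccccc3Oc3ccc(O)c(O)c3)CC2)cc1`, gives 31% in this assay, and the gap between these two numbers lies within the usual scatter of repeated measurements, so neither compound can be ranked above the other on what has been recorded. Among the compounds with values here, compound 1 and compound 2 differ in more than one place, so no single step between them is defined.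

Compound 3, with the structure `O=S(=O)(c1sccc1-c1ccccc1Oc1ccc(O)c(O)c1)N1CCN(C(=S)Nc2cc(C(F)(F)F)cc(C(F)(F)F)c2)CC1`, has not yet been measured in this assay. It differs from compound 2 in one place: 3,4-dihydroxyphenyl in place of 3,4-dimethoxyphenyl on an oxygen on an aromatic ring. Compound 1 already carries the 3,4-dihydroxyphenyl group and gives 31%, and compound 2 with the 3,4-dimethoxyphenyl group gives 25%, so the available numbers offer no sign that this exchange moves the read-out beyond the scatter. The step of a number 4 percentage points higher from compound 2 to compound 3 (within the scatter) is therefore expected to be small. For compound 3 the estimate in this assay is 29%, with a range from 15% to 43%.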

Compound 3, a percentage reported as inhibition, at one concentration (the size of the read-out at that concentration, not a potency): 20%
Beside the measured number, compound 3's estimate is 9 percentage points above it; the range from low to high includes it.
By their numbers in this assay, from the lowest: compounds 3, 2 and 1 (each within the scatter of the next, the first and the last beyond it).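

In this assay the exchange of 3,4-dimethoxyphenyl for 3,4-dihydroxyphenyl on an oxygen on an aromatic ring now has a direct reading, a number 5 percentage points lower from compound 2 to compound 3 (within the scatter), whereas the earlier pair differed in more than one place and offered no such reading. With the rest of the structure held constant, the hydrogen-bond donors that enter with the 3,4-dihydroxyphenyl group, and the loss of the two methyl groups of the 3,4-dimethoxyphenyl group, leave the read-out without a shift beyond the scatter at this position. Nothing recorded here explains this outcome, and no independent measurement bears on it.

What the compounds shown leave open is whether a quite different group on that oxygen, such as an unsubstituted phenyl, a pyridine ring or a chain ending in a carboxylic acid, would separate from the 3,4-dimethoxyphenyl and 3,4-dihydroxyphenyl groups in this assay at all. Also open is where a ring carrying a single hydroxyl or a single methoxy group would stand, and how any of these compounds would read at other concentrations, since a single-concentration figure is not a potency.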